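The compounds below may be only part of what the source reports. "The series", "measured", "known", "first", "only" and "open" are said of these compounds alone.

Measured in an ADME assay on THP-1 cells (Homo sapiens) for cytotoxicity, read by resazurin assay, with a stated time of 72 h; a lower number here means that less compound is tolerated, a higher number that more compound is tolerated:

compound 1 `CSc1ccc(C(=O)/C=C/c2ccc([N+](=O)[O-])o2)cc1` – 13100 nM
compound 2 `CCCCc1ccc(C(=O)/C=C/c2ccc([N+](=O)[O-])o2)cc1` – 48700 nM
compound 3 `O=C(/C=C/c1ccc([N+](=O)[O-])o1)c1ccc(N2CCNCC2)cc1` – > 50000 nM

Compound 3 sits at the top of this small set, and its value in this assay is a limit of the assay rather than a number (the limit of > 50000 nM in this assay, at which 1 of the 3 values shown sits). The next compound in the series is compound 4 `O=C(/C=C/c1ccc([N+](=O)[O-])o1)c1ccc(N2CCCC2)cc1`, which differs from compound 3 in one place: pyrrolidin-1-yl in place of piperazin-1-yl on an aromatic carbon.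

For the measured compounds named here, two measured steps touch the piperazin-1-yl group that is now replaced. The step of an at least 3.8-fold higher number from compound 1 to compound 3 (0.58 log units; beyond the scatter) and the step of an at least 1.0-fold higher number from compound 2 to compound 3 (0.01 log units; that floor lies within the scatter) show that the piperazin-1-yl compound tolerates as much or more compound than either the methylsulfanyl or the butyl analogue, but because compound 3 only reaches a limit, the true size of these steps is open. With compound 2 and compound 3 not resolved from each other in this assay, the change to pyrrolidin-1-yl is expected to move the number little, if at all, beyond the scatter; the expected step is an at least 1.4-fold lower number from compound 3 to compound 4 (0.15 log units; that floor lies within the scatter). Compound 4 is therefore estimated at 35000 nM in this assay, within a range from 12000 nM to 90000 nM, with a fair chance that only a limit is again reported.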

Compound 4, half-maximal cytotoxic concentration: > 50000 nM
Compound 4: no number, only a limit (the forecaster's own chance of this, stated with the estimate: 35%); at least 1.4-fold (0.15 log units) between middle value and limit.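

In this assay compound 4 gives > 50000 nM, which is a limit and not a number, and the series now has two compounds there: the limit of > 50000 nM in this assay, at which 2 of the 4 values shown sit.

Reaching this limit therefore does not require the second ring nitrogen of piperazin-1-yl, since pyrrolidin-1-yl, with 0 hydrogen-bond donors, on the same aromatic carbon also gets there. The new group gives an at least 3.8-fold higher number from compound 1 to compound 4 (0.58 log units; beyond the scatter) against methylsulfanyl and an at least 1.0-fold higher number from compound 2 to compound 4 (0.01 log units; that floor lies within the scatter) against butyl, while the step between the two limits cannot be read.

Going by these compounds, how far the piperazin-1-yl and pyrrolidin-1-yl compounds lie above the limit, and whether they differ at all, remains open. Also open, on these data alone, is whether an open-chain amine such as dimethylamino or a carboxylic acid on this carbon would stay at the limit or fall toward the methylsulfanyl value.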